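The source may hold more compounds than are shown below. What is called first, only, known or untested is meant among the compounds shown, and "the series" means these compounds.

Compound 1 `NC(=O)c1c(NC(=O)c2ccccc2Cl)sc2c1CCN(Cc1cc(Cl)cc(Cl)c1)C2` gives 23700 nM in a functional assay on MKN-74 cells (Homo sapiens) for antiproliferative activity, with a stated time of 24 h; a lower number here means a stronger inhibitor, a higher number a weaker inhibitor.
Compound 2 `Cc1ccc(C(=O)Nc2sc3c(c2C(N)=O)CCN(Cc2c(Cl)cccc2Cl)C3)cc1` gives 12300 nM in this assay.
Compound 3 `NC(=O)c1c(NC(=O)c2ccccc2F)sc2c1CCN(Cc1c(Cl)cccc1Cl)C2` gives 7430 nM in this assay.

Among these three numbers, compound 1 stands highest: compound 2 lies nearest to it, within the scatter, while compound 3 lies furthest, beyond it. Compound 4 `NC(=O)c1c(NC(=O)c2ccccc2Cl)sc2c1CCN(C(=S)Nc1c(Cl)cccc1Cl)C2` differs from compound 1 in one place: a group of 11 heavy atoms (7 carbon, 1 nitrogen, 1 sulfur, 2 chlorine; one six-membered aromatic ring of carbon only) in place of a group of 9 heavy atoms (7 carbon, 2 chlorine; one six-membered aromatic ring of carbon only), on an amine nitrogen in a ring. Within the data shown here, the single measured step, a 1.7-fold lower number from compound 2 to compound 3 (0.22 log units; within the scatter), alters the group on the carbonyl carbon, not the group on the ring amine nitrogen, so it does not bear on this change. Among the measured compounds shown here, no measured step covers a change at that nitrogen, and no step beyond the scatter is therefore expected in this assay. Compound 4 is estimated at 20000 nM, with a range from 5000 nM to 80000 nM, which would be a step of a 1.2-fold lower number from compound 1 to compound 4 (0.07 log units; within the scatter).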

Compound 4, half-maximal inhibitory concentration: 4020 nM
Compound 4: middle estimate off by 5.0-fold (0.70 log units), on the high side; measured number outside the range, below it.
By their numbers in this assay, from the lowest: compounds 4, 3, 2 and 1 (each within the scatter of the next, the first and the last beyond it).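

At the amine nitrogen in a ring, the change of group does register in this assay: with the 3,5-dichlorobenzyl group replaced by the group holding sulfur and nitrogen, there is a 5.9-fold lower number from compound 1 to compound 4 (0.77 log units; beyond the scatter). Among these compounds, this is the first step beyond the scatter between compounds that differ in one place, as the earlier step altered only the group on a carbonyl carbon. Nothing measured here accounts for this step.

On these data alone, it remains open which part of the entering group goes with the step. Also open, as far as these compounds go, is whether an acetyl group or a longer chain ending in an amine on this nitrogen would give a lower number still.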